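Enantiomer swap in a urea series: compound 3 expected

A few compounds are considered here, and "the series" means these few. Any claim that something is new, unique, unknown or untested is made for them only; others in the source may bear on it.

Measured so far:
compound 1, `Cc1ccc(NC(=O)N[C@@H](C)c2ccccc2)cc1`: 100%
compound 2, `CC(C)c1ccc(NC(=O)N[C@H](C)c2ccccc2)cc1`: 99%

Two ureas have been measured in an ADME assay on the whole organism with Oryza sativa as the target, tested at 0.1 uM; on this read-out higher numbers stand for a weaker effect at the one concentration tested and lower numbers for a stronger effect. In this assay compound 1 gives 100% and compound 2 gives 99%. Compound 2 has the lower of the two numbers, but the gap to compound 1 lies within the usual scatter, so the two compounds cannot be told apart on this read-out.

The next compound, compound 3, `CC(C)c1ccc(NC(=O)N[C@@H](C)c2ccccc2)cc1`, is still to be measured in this assay. It differs from compound 2 as follows: the two compounds have the same atoms and bonds and differ only in configuration as drawn: 1 of 1 stereo elements differ; a stereocentre at a saturated chain carbon is drawn R in compound 2 and S in compound 3.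

Going by the values given here, no step between measured compounds is available to gauge such a change, and both measured compounds sit at the top of the scale in this assay. The step from compound 2 to compound 3 is therefore expected to be no larger than the scatter, no change at the digits printed from compound 2 to compound 3 (within the scatter). Compound 3 is expected to give 99% in this assay, with a range from 90% to 100%.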

Compound 3, a percentage reported as activity, at one concentration (the size of the read-out at that concentration, not a potency): 98%
The estimate for compound 3 lay 1 percentage points above the measured number; measured number inside the range.
By their numbers in this assay, from the lowest: compounds 3, 2 and 1 (each within the scatter of the next).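

Going by these compounds alone, for the first time, the stereocentre at the saturated chain carbon is seen on its own: in this assay, drawing it S rather than R gives a number 1 percentage points lower from compound 2 to compound 3 (within the scatter), so configuration at this centre shows no readable effect at the one concentration tested. This reading is a clean one, as only one structural difference separates the pair: the fact that compounds 2 and 3 differ only in the configuration as drawn. The same holds for isopropyl in place of methyl on an aromatic carbon, which gives a number 2 percentage points lower from compound 1 to compound 3 (within the scatter), so this change also cannot be told apart from scatter in this assay.

As far as these compounds go, all three compounds sit at the top of the scale, so it stays open whether either change would matter in a compound with a stronger effect. Also open, from the compounds shown here alone, is whether a carboxylic acid, an amine or a longer chain in place of isopropyl would move the number at all.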